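Compound 3: hydrogen in place of ethyl

A few compounds are considered here, and "the series" means these few. Any claim that something is new, unique, unknown or untested is made for them only; others in the source may bear on it.

In a functional assay on SF-268 cells (Homo sapiens) for antiproliferative activity, read by sulforhodamine B assay, with a stated time of 72 h (on this read-out higher numbers stand for weaker inhibition and lower numbers for stronger inhibition), compound 1 `O=C1CS/C(=N/Nc2nncc3ccccc23)N1c1ccccc1` gives 7 nM and compound 2 `CCN1C(=O)CS/C1=N/Nc1nncc2ccccc12` gives 6 nM, leaving compound 2 level with compound 1 within the scatter. Compound 3 `O=C1CS/C(=N/Nc2nncc3ccccc23)N1` has hydrogen in place of ethyl on an amide-type nitrogen in a ring, (hydrogen in place of ethyl on an amide-type nitrogen in a ring). Among the compounds with values here, the only measured step at this place is a 1.2-fold lower number from compound 1 to compound 2 (0.07 log units; within the scatter), with ethyl in place of phenyl. Within the data shown here, no compound with hydrogen there has a measured value, so only a small rise in the number is expected, none beyond the scatter. The expected change is a 1.7-fold higher number from compound 2 to compound 3 (0.22 log units; within the scatter). For compound 3 the estimated value is 10 nM, with an expected range of 3 nM to 35 nM.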

Compound 3, half-maximal inhibitory concentration: 6 nM
The estimate for compound 3 lay 1.7-fold (0.22 log units) above the measured number, and the stated range covers the measured number.
By their numbers in this assay, from the lowest: compounds 2, 3 and 1 (each within the scatter of the next).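

Taking the substituent off the ring nitrogen altogether does not shift the read-out in this assay: there is no change at the digits printed from compound 2 to compound 3 (within the scatter), and a 1.2-fold lower number from compound 1 to compound 3 (0.07 log units; within the scatter). On this amide-type nitrogen, hydrogen therefore stands level with both ethyl and phenyl, so across these three compounds the number does not depend on which of the three groups is present. Nothing available gives a reason for this flat result.

Going by these compounds, whether a longer chain, an amine or a carboxylic acid on this nitrogen would also stay level remains open. So does whether changes elsewhere on the shared core would move the number.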